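A few compounds are considered here, and "the series" means these few. Any claim that something is new, unique, unknown or untested is made for them only; others in the source may bear on it.

Measured so far in an ADME assay on microsomes from liver (Mus musculus) for metabolic stability; a lower number here means slower removal, a higher number faster removal of the compound:
compound 1 `O=C(O)Cn1nc(Cc2nc3cc(F)c(OCC4CC4)cc3[nH]2)c2ccccc2c1=O`: < 53.4 mL/min/kg
compound 2 `C[C@H](C(=O)O)c1nn(Cc2cn3cc(OCC4CC4)c(Cl)cc3n2)c2ccccc2c1=O`: < 53.4 mL/min/kg

The value for compound 1 is a limit of the assay, not a number. The value for compound 2 is likewise a limit. On this assay, then, compound 1 stands where every value shown stands: the limit of < 53.4 mL/min/kg in this assay, at which 2 of the 2 values shown sit. No difference between the two measured compounds can be sized from limits alone.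

Compound 3 `O=C(O)Cn1nc(Cc2nc3cc(C(F)(F)F)c(OCC4CC4)cc3[nH]2)c2ccccc2c1=O` differs from compound 1 at the ring position ortho to the cyclopropylmethoxy group: trifluoromethyl in place of fluoro on an aromatic carbon. With both measured values sitting at the limit, no step beyond the scatter is expected here; compound 3 is expected to remain near that limit as well. The estimate for compound 3 is 40 mL/min/kg, in the range 18 mL/min/kg to 85 mL/min/kg. The step expected from compound 1 to compound 3 is a step that the limit leaves unreadable from compound 1 to compound 3.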

Compound 3, clearance: < 88.4 mL/min/kg
Compound 3: a limit, no number (the forecaster's own chance of this, stated with the estimate: 55%); the middle value does not contradict the limit.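

Among the compounds shown here, no step from compound 1 to compound 3 can be read in this assay: each gives only a limit, not a number. Going by these compounds, the actual clearance of compound 1 and compound 3 stays open, and with it any difference between fluoro and trifluoromethyl.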